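Swapping a large aryl group for methyl

The source may hold more compounds than are shown below. What is called first, only, known or untested is meant among the compounds shown, and "the series" means these compounds.

Measured in a functional assay on HepG2 cells (Homo sapiens) for inhibition, read by MTT assay, with a stated time of 72 h; on this read-out lower numbers stand for stronger inhibition and higher numbers for weaker inhibition:
- Compound 1 `CC(C)(C)n1cc2c(n1)C(=O)CC1(CCN(C(=O)c3cc(-c4ccc(F)cc4)nc4ccccc34)CC1)O2`: 2930 nM
- Compound 2 `COc1ccc(-c2cc(C(=O)N3CCC4(CC3)CC(=O)c3nn(C(C)(C)C)cc3O4)c3ccccc3n2)cc1`: 2780 nM
- Compound 3 `CN(C)c1ccc(-c2cc(C(=O)N3CCC4(CC3)CC(=O)c3nn(C(C)(C)C)cc3O4)c3ccccc3n2)cc1`: 1730 nM

Compound 3 gives 1730 nM, which lies within the usual scatter of both other values, so no order among the three can be claimed.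

Compound 4 `Cc1cc(C(=O)N2CCC3(CC2)CC(=O)c2nn(C(C)(C)C)cc2O3)c2ccccc2n1` has not yet been measured. Its difference from compound 3 is methyl in place of 4-(dimethylamino)phenyl on an aromatic carbon, next to the ring nitrogen.

Within the data shown here, three measured steps bear on this change, and each exchanges only fluoro, methoxy or dimethylamino on an aromatic carbon: a 1.1-fold lower number from compound 1 to compound 2 (0.02 log units; within the scatter), a 1.7-fold lower number from compound 1 to compound 3 (0.23 log units; within the scatter) and a 1.6-fold lower number from compound 2 to compound 3 (0.21 log units; within the scatter). All three stay within the scatter, but none removes the aromatic ring that compound 4 lacks. The data therefore offer no direct measure of this much larger change, and their flatness cannot simply be carried over to it.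

All three measured compounds carry that ring, so a step beyond the scatter towards a higher number, meaning weaker inhibition, is expected, though on thin evidence. The expected change is a 4.6-fold higher number from compound 3 to compound 4 (0.67 log units; beyond the scatter). For compound 4 the estimated value is 8000 nM, with an expected range from 2500 nM to 30000 nM.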

Compound 4, half-maximal inhibitory concentration: 9480 nM
For compound 4 the middle estimate is 1.2-fold (0.07 log units) below the measured one, within the range that was stated.
By their numbers in this assay, from the lowest: compounds 3, 2 and 1 (each within the scatter of the next); then compound 4.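

In this assay, the place on an aromatic carbon next to the ring nitrogen responds clearly to losing the whole aryl group: methyl gives a 5.5-fold higher number from compound 3 to compound 4 (0.74 log units; beyond the scatter), a 3.4-fold higher number from compound 2 to compound 4 (0.53 log units; beyond the scatter) and a 3.2-fold higher number from compound 1 to compound 4 (0.51 log units; beyond the scatter). The earlier compounds shown here showed only that fluoro, methoxy and dimethylamino on the outer ring could be exchanged without leaving the scatter, whereas these steps show that all three aryl compounds stand apart from the methyl compound, by a modest margin, even though they do not stand apart from one another. What the measurements here do not provide is any explanation of this loss of inhibition.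

The change removes an aromatic ring and shortens the group at once, so the compounds shown cannot tell whether the ring itself matters or simply a group larger than methyl. An unsubstituted phenyl, a saturated cyclohexyl ring or a longer alkyl chain such as butyl at this place would help separate those two readings, and a pyridyl ring would test whether the outer ring has to be carbon only.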